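Dimethylamino in place of hydroxy: expected step

A few compounds are considered here, and "the series" means these few. Any claim that something is new, unique, unknown or untested is made for them only; others in the source may bear on it.

Values measured in a functional assay on Hs-578T cells (Homo sapiens) for inhibition (a higher number here means a weaker inhibitor of growth, a lower number a stronger inhibitor of growth), for the series so far:
- compound 1 `NS(=O)(=O)c1ccc(/C=C/c2ccc(O)c(O)c2)cc1` gives 25600 nM
- compound 2 `NS(=O)(=O)c1ccc(/C=C/c2ccc(F)cc2)cc1` gives 23700 nM
- compound 3 `NS(=O)(=O)c1ccc(/C=C/c2ccc(O)cc2)cc1` gives 28900 nM

Compound 3 at 28900 nM lies within the scatter of the other two values, so no order can be read among these three compounds.

The next compound is compound 4 `CN(C)c1ccc(/C=C/c2ccc(S(N)(=O)=O)cc2)cc1` and it is reached from compound 3 by a single change: dimethylamino in place of hydroxy on an aromatic carbon that is, dimethylamino in place of hydroxy on an aromatic carbon.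

For the measured compounds named here, two measured steps bear on this change. One is a 1.2-fold higher number from compound 2 to compound 3 (0.09 log units; within the scatter) for hydroxy in place of fluoro on an aromatic carbon. The other is a 1.1-fold higher number from compound 1 to compound 3 (0.05 log units; within the scatter) for hydrogen in place of hydroxy on an aromatic carbon. Both lie within the scatter. Going by the values given here, no measured compound carries dimethylamino, so these steps are only a weak guide to the new group.

On these two steps no change beyond the scatter is expected in this assay and no firm direction can be given. The estimated step is a 1.3-fold lower number from compound 3 to compound 4 (0.12 log units; within the scatter) and it is expected to stay within the scatter. For compound 4 the estimated value is 22000 nM with an expected range from 8000 nM to 45000 nM as the working figure.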

Compound 4, concentration for 50% growth inhibition: 3030 nM
Compound 4: middle estimate off by 7.3-fold (0.86 log units), on the high side; the measured number lies below the stated range.
By their numbers in this assay, from the lowest: compound 4; then compounds 2, 1 and 3 (each within the scatter of the next).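

In this assay, the aromatic carbon para to a large group no longer looks indifferent to its substituent. Among the earlier compounds, hydroxy and fluoro gave no step beyond the scatter (a 1.2-fold higher number from compound 2 to compound 3 (0.09 log units; within the scatter)), and neither did removing the second hydroxy (a 1.1-fold higher number from compound 1 to compound 3 (0.05 log units; within the scatter)), whereas dimethylamino gives a clear step in place of hydroxy (a 9.5-fold lower number from compound 3 to compound 4 (0.98 log units; beyond the scatter)) and in place of fluoro (a 7.8-fold lower number from compound 2 to compound 4 (0.89 log units; beyond the scatter)). The two new steps agree in direction and show that this position can carry a change in growth inhibition, though no measurement on hand explains why dimethylamino differs from the other groups.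

Dimethylamino is the only nitrogen-bearing group at this position, so the series cannot yet separate the contribution of the nitrogen from that of the two added carbons and the loss of the hydrogen-bond donor. A primary amine, methylamino, diethylamino, pyrrolidine or methoxy at the same carbon would show whether the step depends on the amine, on its substitution or on neither.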